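A few compounds are considered here, and "the series" means these few. Any claim that something is new, unique, unknown or untested is made for them only; others in the source may bear on it.

Compound 2, `O=C(O)CNC(=O)Nc1ccc(F)c(C(F)(F)F)c1`, carries a carboxymethyl group on an amide-type nitrogen of a urea. In a physicochemical assay for solubility, read by nephelometry, in phosphate buffer, measured as kinetic solubility, at pH 6.5, tested at 10 mg/mL (a lower number here means a less soluble compound, a higher number a more soluble compound), compound 2 gives > 100 ug/mL, which is a limit of the assay rather than a measured number. Compound 1, `CC(C)(NC(=O)Nc1ccc(F)c(C(F)(F)F)c1)C(=O)O`, bears a 1-carboxy-1-methylethyl group in the same place. In this assay compound 1 gives > 100 ug/mL, also a limit. The step that the two limits leave unreadable from compound 1 to compound 2 thus has no readable size, since both values sit at the limit of > 100 ug/mL in this assay, at which 2 of the 2 values shown sit. Compound 3, `O=C(Nc1ccc(F)c(C(F)(F)F)c1)NC1(C(=O)O)CC1`, is the next change: 1-carboxycyclopropyl in place of carboxymethyl on an amide-type nitrogen. Among the compounds with values here, the only measured step on this nitrogen, swapping one small acid-bearing group for another, left no readable size, and the present swap is of the same kind. For compound 3 the expected step that the limit leaves unreadable from compound 2 to compound 3 is none beyond the scatter. Compound 3 is therefore estimated at 120 ug/mL, within 60 ug/mL to 240 ug/mL, most likely reported again only as a limit.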

Compound 3, solubility: > 100 ug/mL
Compound 3 was reported as a limit (the forecaster's own chance of this, stated with the estimate: 70%); the middle value does not contradict the limit.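

Compound 3, like compound 1 and compound 2, is reported only as a limit, so no step among these three compounds can be read: the limit of > 100 ug/mL in this assay, at which 3 of the 3 values shown sit. The compounds shown leave open whether their groups on the amide-type nitrogen differ at all in this assay, and by how much.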